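This account rests on a few compounds, and the source may have more. Where it says the series, first, only, none or still open, it means among the compounds named here.

In an assay for inhibition of inositol hexakisphosphate kinase 2 (Homo sapiens), read by colorimetric assay, coupled enzyme assay and malachite green, with a stated time of 120 min, in the presence of a further agent that is not named here (a higher number here means a weaker inhibitor, a lower number a stronger inhibitor), the measured compounds are:
compound 1, `O=C(O)c1ccc2noc(-c3ccc(Cc4ccccc4)cc3)c2c1`, 65 nM
compound 2, `O=C(O)c1ccc2noc(-c3ccc(Oc4ccccn4)cc3)c2c1`, 1190 nM
compound 3, `CC(C)NC(=O)c1ccc(-c2onc3ccc(C(=O)O)cc23)cc1`, 350 nM

Compound 3 stands second highest of the three numbers: the step of a 5.4-fold higher number from compound 1 to compound 3 (0.73 log units; beyond the scatter) and the step of a 3.4-fold lower number from compound 2 to compound 3 (0.53 log units; beyond the scatter) are both beyond the scatter. Compound 4, `O=C(O)c1ccc2noc(-c3ccc(NC(=O)c4ccccc4)cc3)c2c1`, differs from compound 3 by benzamido in place of isopropylcarbamoyl on an aromatic carbon. Of the measured steps, a 5.4-fold higher number from compound 1 to compound 3 (0.73 log units; beyond the scatter) bears most on this change; compound 1 too carries an aromatic ring at that carbon. The step of an 18-fold higher number from compound 1 to compound 2 (1.26 log units; beyond the scatter) shows that a second ring alone does not secure a low number. A modest fall is therefore expected for compound 4, a 2.3-fold lower number from compound 3 to compound 4 (0.37 log units; beyond the scatter). Compound 4 is estimated at 150 nM, with a range from 50 nM to 500 nM.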

Compound 4, half-maximal inhibitory concentration: 580 nM
Beside the measured number, compound 4's estimate is 3.9-fold (0.59 log units) below it, outside the stated range (above it).
By their numbers in this assay, from the lowest: compound 1; then compounds 3 and 4 (each within the scatter of the next); then compound 2.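

In this assay, an aromatic ring brought in through benzamido does not carry the low number of compound 1 over to this carbon: an 8.9-fold higher number from compound 1 to compound 4 (0.95 log units; beyond the scatter) separates benzamido from benzyl, whereas a 1.7-fold higher number from compound 3 to compound 4 (0.22 log units; within the scatter) leaves benzamido and the ring-free isopropylcarbamoyl unresolved. With a 2.1-fold lower number from compound 2 to compound 4 (0.31 log units; beyond the scatter) as well, compound 1, compound 2 and compound 4 all carry a second ring at this carbon, yet their numbers differ with the link to that ring. Nothing given here explains these differences. The compounds shown leave open whether a longer chain joining the two rings, or an amine on the outer ring of compound 1, would keep its low number.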